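The source may hold more compounds than are shown below. What is called first, only, known or untested is meant among the compounds shown, and "the series" means these compounds.

Measured compounds:
- compound 1, `CN(C)CCN1CCN(c2nc(-c3ccccn3)nc3c2CN(Cc2ccccc2)CC3)CC1`: 57%
- compound 2, `CN(C)CCN1CCN(c2nc(-c3cccnc3)nc3c2CN(Cc2ccccc2)CC3)CC1`: "not active" (no number reported)
- compound 3, `CN1CCN(CCCNc2nc(-c3ccncc3)nc3c2CN(Cc2ccccc2)CC3)CC1`: "not active" (no number reported)

Among the measured compounds shown here, in an assay on A549 cells with Cystic fibrosis transmembrane conductance regulator variant F508del (Homo sapiens) as the target, read by fluorescence, with a stated time of 25 min (a higher number here means a larger maximal response, a lower number a smaller maximal response), compound 3 stands with no number at all: it is reported as "not active" (no number reported), and compound 2 shares that fate, so the only number in this set belongs to compound 1. Compound 4, `CN(C)CCN1CCN(c2nc(-c3ccncc3)nc3c2CN(Cc2ccccc2)CC3)CC1`, keeps every atom of compound 3 but joins them differently: 4-(2-(dimethylamino)ethyl)piperazin-1-yl in place of (3-(4-methylpiperazin-1-yl)propyl)amino on an aromatic carbon. The change puts compound 4 on the same side-chain arrangement as compound 1 and compound 2, while keeping the pyridin-4-yl group of compound 3.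

For the measured compounds named here, no measured step between two compounds is available here, so the size of the move from compound 3 to compound 4 in this assay cannot be taken from a comparison. Compound 1 shows that a response of moderate size is reachable with the entering group, but compound 2, with the same entering group, gives nothing, and compound 3 gives nothing with the pyridin-4-yl group. The expectation for compound 4 is therefore a small response at most, quite possibly again without a number. Compound 4 is estimated at 15%, in a range from 0% to 45%.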

Compound 4, largest response reached (Emax), in percent of the reference or control that the assay uses in the Cystic fibrosis transmembrane conductance regulator assay: "not active" (no number reported)
No number was reported for compound 4, and the estimate cannot be compared.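

Among the compounds shown here, compound 3 and compound 4 are both reported as not active in the Cystic fibrosis transmembrane conductance regulator assay, so no step between them can be read there. In a physicochemical assay for solubility, read by HPLC, with a stated time of 24 h, at pH 7.4, tested at 250 uM (on this read-out higher numbers stand for higher solubility and lower numbers for lower solubility), compound 3 gives 250000 nM and compound 4 gives 250000 nM as well. The compounds shown leave open why compound 1 gives a response and compound 4 does not, and no measurement here offers a reason.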